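Amide substituent changes on a shared core

A few compounds are considered here, and "the series" means these few. Any claim that something is new, unique, unknown or untested is made for them only; others in the source may bear on it.

Measured so far in a functional assay on MCF7 cells (Homo sapiens) for antiproliferative activity, read by MTT assay, with a stated time of 48 h; on this read-out lower numbers stand for stronger inhibition and higher numbers for weaker inhibition:
Compound 1, `CCn1c(C(=O)NCCN(C)C)ccc1C(CC)(CC)c1ccc(OCCC(O)(CC)CC)c(C)c1`, gives 430 nM.
Compound 2, `C#CCCOC(=O)c1ccc(C(CC)(CC)c2ccc(OCCC(O)(CC)CC)c(C)c2)n1CC`, gives only a limit, > 50000 nM.
Compound 3, `CCOc1ccc(NC(=O)c2ccc(C(CC)(CC)c3ccc(OCCC(O)(CC)CC)c(C)c3)n2CC)cc1`, gives only a limit, > 50000 nM.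

Among the measured compounds shown here, compound 1 stands as the only number among the three; the other two sit at the limit of > 50000 nM in this assay, at which 2 of the 3 values shown sit. Both changes made to it on the carbonyl side cost heavily: an at least 110-fold higher number from compound 1 to compound 2 (2.06 log units; beyond the scatter), and an at least 110-fold higher number from compound 1 to compound 3 (2.06 log units; beyond the scatter). Between the two limit compounds the step that the two limits leave unreadable from compound 2 to compound 3.

Compound 4, `CCn1c(C(=O)NC(C)CO)ccc1C(CC)(CC)c1ccc(OCCC(O)(CC)CC)c(C)c1`, is not yet measured. It differs from compound 1 in one place: 1-(hydroxymethyl)ethyl in place of 2-(dimethylamino)ethyl on an amide-type nitrogen. The step that bears on this most directly is an at least 110-fold higher number from compound 1 to compound 3 (2.06 log units; beyond the scatter), which alters the same amide-type nitrogen, but there a 4-ethoxyphenyl entered; in compound 4 an open chain with a hydroxyl enters, and the amide hydrogen stays. The step of an at least 110-fold higher number from compound 1 to compound 2 (2.06 log units; beyond the scatter) shows a second way of losing the (2-(dimethylamino)ethyl)amino group that also reaches the limit. A rise in number is therefore expected, but smaller than either measured step, since the shape of the side chain is closer to that of compound 1.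

The expected step is a 7.0-fold higher number from compound 1 to compound 4 (0.84 log units; beyond the scatter). For compound 4 the estimated value is 3000 nM, with a range from 700 nM to 15000 nM.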

Compound 4, half-maximal inhibitory concentration: 12600 nM
For compound 4 the middle estimate is 4.2-fold (0.62 log units) below the measured one; the range from low to high includes it.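

In this assay, the amide-type nitrogen gets its first readable step without the 2-(dimethylamino)ethyl group, as 1-(hydroxymethyl)ethyl gives a 29-fold higher number from compound 1 to compound 4 (1.47 log units; beyond the scatter); the loss at this position can therefore stay short of the assay limit. The position also separates two replacements, with an at least 3.9-fold lower number from compound 3 to compound 4 (0.59 log units; beyond the scatter), and the amide compares in the same way with the ester on the carbonyl carbon, with an at least 3.9-fold lower number from compound 2 to compound 4 (0.59 log units; beyond the scatter). Both of these steps are bounded rather than exact, and the step between compound 2 and compound 3 cannot be read, as each of those compounds gives only a limit and not a number: the limit of > 50000 nM in this assay, at which 2 of the 4 values shown sit.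

The compounds shown leave open whether the difference from compound 1 follows the dimethylamino group itself or the chain that carries it, a question that a 3-(dimethylamino)propyl or a 2-(diethylamino)ethyl group on the same nitrogen would address. Also open, as far as these compounds go, is how a plain 2-hydroxyethyl group or a morpholine-bearing ethyl chain would read there, and so how much of the step from 2-(dimethylamino)ethyl to 1-(hydroxymethyl)ethyl belongs to the hydroxyl and how much to the amine leaving.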